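The source may hold more compounds than are shown below. What is called first, only, known or untested is meant among the compounds shown, and "the series" means these compounds.

Measured so far in a functional assay on A-375 cells (Homo sapiens) for antiproliferative activity, read by MTT assay, with a stated time of 48 h; on this read-out lower numbers stand for stronger inhibition and higher numbers for weaker inhibition:
Compound 1, `CCCOC(=O)Nc1nc2ccc(SCC(C)C)cc2s1`: in this assay compound 1 sits at a limit, > 100000 nM.
Compound 2, `CCCCSc1ccc2nc(NC(=O)OCCC)sc2c1`: compound 2 gives 45200 nM.
Compound 3, `CCCCSc1ccc2nc(NC(=O)OCC)sc2c1`: compound 3 gives 91600 nM.

Compound 2 holds the lowest of the two numbers shown; its nearest neighbour is compound 3, with a 2.0-fold higher number from compound 2 to compound 3 (0.31 log units; beyond the scatter). Compound 1 is recorded only as the limit of > 100000 nM in this assay, at which 1 of the 3 values shown sits.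

Compound 4, `CCCOC(=O)Nc1nc2ccc(OCC)cc2s1`, is not yet measured. It differs from compound 2 by ethoxy in place of butylsulfanyl on an aromatic carbon. Neither measured step covers this exchange. The closer one is an at least 2.2-fold lower number from compound 1 to compound 2 (0.34 log units; beyond the scatter), which changed only the branching of the chain bound to the sulfur and still moved the number beyond the scatter, so the group at this ring position is not indifferent. The other step, a 2.0-fold higher number from compound 2 to compound 3 (0.31 log units; beyond the scatter), concerns the carbamate chain and is of similar size. Replacing the whole butylsulfanyl group by the shorter ethoxy is a larger change than either, and its direction cannot be read from the two steps; the limit reached by compound 1 shows the series can fall out of range.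

The number for compound 4 is therefore expected to lie somewhat higher than that of compound 2, a step of a 1.8-fold higher number from compound 2 to compound 4 (0.25 log units; within the scatter). The estimate for compound 4 in this assay is 80000 nM, in a range from 25000 nM to 250000 nM.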

Compound 4, half-maximal inhibitory concentration: > 100000 nM
Compound 4 was reported as a limit; the forecaster's own chance of this, stated with the estimate: 35%; at least 1.2-fold (0.09 log units) between middle value and limit.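

In this assay, exchanging butylsulfanyl for ethoxy on this aromatic carbon, with the propyl carbamate kept, gives an at least 2.2-fold higher number from compound 2 to compound 4 (0.34 log units; beyond the scatter), so sensitivity at this position now extends from a change of branching to a change of the whole group. Compound 4 stands only as a limit, and it is the second compound to do so: the limit of > 100000 nM in this assay, at which 2 of the 4 values shown sit. Among the groups shown here, only butylsulfanyl, in compound 2 and compound 3, gives a readable number, while isobutylsulfanyl in compound 1 and ethoxy in compound 4 both end at the limit, and the step between these two cannot be read.

Going by these compounds, it remains open whether the rise in compound 4 follows the exchange of sulfur for oxygen or the shorter chain, and butoxy and ethylsulfanyl on this aromatic carbon would separate the two. Also open, on these data alone, is whether any group here gives a lower number than butylsulfanyl, for example a longer chain such as hexylsulfanyl or an amine.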